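The source may report more compounds than this note shows. Statements on the series, on what has been measured and on what is new or still open speak of the compounds shown alone.

Compound 1 `O=S(=O)(c1ccccc1)c1nc2ccccc2nc1N1CCCC1`: 34800 nM
Compound 2 `COc1ccc(S(=O)(=O)c2nc3ccccc3nc2N2CCCC2)cc1`: > 50000 nM (a limit of the assay, not a number)
Compound 3 `O=S(=O)(c1ccccc1)c1nc2ccccc2nc1N1CCc2ccccc2C1`: 19800 nM
Compound 4 `O=S(=O)(c1ccc(F)cc1)c1nc2ccccc2nc1N1CCc2ccccc2C1`: not yet measured

In a functional assay on A549 cells (Homo sapiens) for cytotoxicity, read by MTT assay, with a stated time of 72 h (a higher number here means a weaker inhibitor, a lower number a stronger inhibitor), compound 3 gives 19800 nM and compound 1 gives 34800 nM. These two numbers lie within the usual scatter of each other, so they do not separate the two compounds. Compound 2 reads > 50000 nM, which is a limit and not a number.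

Compound 4 keeps everything in compound 3 except for one change: fluoro in place of hydrogen on an aromatic carbon, so that phenyl becomes 4-fluorophenyl (fluoro in place of hydrogen on an aromatic carbon). For the measured compounds named here, only one measured step resembles this, a different swap on an aromatic carbon, with methoxy in place of hydrogen: an at least 1.4-fold higher number from compound 1 to compound 2 (0.15 log units; that floor lies within the scatter). That step involves another group and starts from another compound, so it offers only a loose guide. Since it shows nothing beyond the scatter, no clear shift is expected from the smaller fluoro change either.

The expected change is a 1.1-fold lower number from compound 3 to compound 4 (0.04 log units; within the scatter), which would be no real step beyond the scatter. Compound 4 is estimated at about 18000 nM, with an expected range from 8000 nM to 40000 nM.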

Compound 4, half-maximal inhibitory concentration: 22900 nM
Estimate against measurement, compound 4: 1.3-fold (0.10 log units) below; measured number inside the range.
By their numbers in this assay, from the lowest: compounds 3, 4 and 1 (each within the scatter of the next). At a limit, above all of these: compound 2.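

In this assay, fluoro in place of hydrogen on an aromatic carbon, para to a large group, gives a 1.2-fold higher number from compound 3 to compound 4 (0.06 log units; within the scatter), so this change does not separate the two compounds. For the compounds shown here, this is the only step on this ring with a true number at both ends, since the earlier methoxy step ends at a limit and could show only a floor, not a size. At this position, with the rest of compound 3 unchanged, adding a single fluorine atom therefore leaves the reading within the usual scatter, and the data shown offer no explanation for this result.

From the compounds shown here alone, whether an amine, a carboxylic acid or a longer chain on the same aromatic carbon would move the number beyond the scatter remains open, since fluoro is a single atom and says little about groups of a different kind. Going by these compounds, it is also open whether fluoro would behave the same way on compound 1, which differs from compound 3 in the group on the other side of the shared core.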